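The source may hold more compounds than are shown below. What is called first, only, known or untested is meant among the compounds shown, and "the series" means these compounds.

Measured in an ADME assay on A549 cells (Homo sapiens) for cytotoxicity, read by resazurin assay, with a stated time of 48 h; on this read-out higher numbers stand for lower toxicity in this test and lower numbers for higher toxicity in this test:

compound 1, `CC(C)Nc1ccc(NC(=O)c2cc(Cl)ccc2O)c(Cl)c1`, gives 11000 nM
compound 2, `O=C(Nc1ccc(NCc2ccc(F)cc2)cc1Cl)c1cc(Cl)ccc1O`, gives 54400 nM
compound 3, `O=C(Nc1ccc(NCc2ccncc2)cc1Cl)c1cc(Cl)ccc1O`, gives 65300 nM

Compound 1 has the lowest of these three numbers, meaning it is the most toxic of the three in this assay; both other compounds sit beyond the scatter above it. Compound 4, `O=C(Nc1ccc(NCc2cccnc2Cl)cc1Cl)c1cc(Cl)ccc1O`, differs from compound 1 by (2-chloropyridin-3-yl)methyl in place of isopropyl on a nitrogen on an aromatic ring. Within the data shown here, two measured steps bear on this change, since each also puts an aromatic-ring-bearing methyl group in place of isopropyl on the same nitrogen: a 4.9-fold higher number from compound 1 to compound 2 (0.69 log units; beyond the scatter) and a 5.9-fold higher number from compound 1 to compound 3 (0.77 log units; beyond the scatter). Both were modest rises of similar size, so a rise of comparable size is expected here, a 4.5-fold higher number from compound 1 to compound 4 (0.66 log units; beyond the scatter). Compound 4 is therefore estimated at 50000 nM, within a range of 20000 nM to 130000 nM.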

Compound 4, half-maximal cytotoxic concentration: 101000 nM
Compound 4: middle estimate off by 2.0-fold (0.31 log units), on the low side; the range from low to high includes it.
By their numbers in this assay, from the lowest: compound 1; then compounds 2, 3 and 4 (each within the scatter of the next).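

In this assay, a third ring-bearing methyl group on this nitrogen again lifts the number clear of the isopropyl compound (a 9.2-fold higher number from compound 1 to compound 4 (0.96 log units; beyond the scatter)), so the rise now extends to (2-chloropyridin-3-yl)methyl. The three ring-bearing groups stay within the scatter of one another (a 1.5-fold higher number from compound 3 to compound 4 (0.19 log units; within the scatter); a 1.9-fold higher number from compound 2 to compound 4 (0.27 log units; within the scatter)), so swapping one ring for another shows no readable effect here. No measurement available explains the rise.

Still open, going by these compounds, is whether a ring is needed at all, which a plain butyl chain on this nitrogen would test. Also open, on these data alone, is whether a ring carrying a carboxylic acid or an amine would keep the number this high.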